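The compounds below may be only part of what the source reports. "The series", "measured", "known", "first", "only" and "open" are said of these compounds alone.

The series shares one core, carried by compound 1 `O=C(NO)c1ccc(NCc2nc(-c3ccc(Br)cc3)nn2-c2ccccc2)cc1`, compound 2 `O=C(NO)c1ccc(NCc2nc(-c3ccc(Br)o3)nn2-c2ccccc2)cc1`, compound 3 `O=C(NO)c1ccc(NCc2nc(-c3ccccc3)nn2-c2ccc(F)cc2)cc1` and the as yet unmeasured compound 4 `O=C(NO)c1ccc(NCc2nc(-c3cc4ccccc4s3)nn2-c2ccccc2)cc1`. In an assay on Sf9 cells for inhibition of protein deacetylase HDAC6 (Homo sapiens), read by fluorescence, with a stated time of 40 min, tested at 100 nM (a higher number here means more inhibition at the concentration tested (going by the name of the read-out), a lower number less inhibition), compound 1 gives 54.7%, compound 2 gives 55.8% and compound 3 gives 67.6%. Compound 2 therefore stands second highest of the three numbers: its nearest neighbour is compound 1, and the two values lie within the scatter of each other, while compound 3 lies beyond the scatter above it. The move from compound 2 to compound 4 is this change: 1-benzothiophen-2-yl in place of 5-bromofuran-2-yl on an aromatic carbon. Within the data shown here, only one measured step touches the same place, the exchange of 4-bromophenyl for 5-bromofuran-2-yl, which gave a number 1.1 percentage points higher from compound 1 to compound 2 (within the scatter). That step, a swap of one aromatic group for another on an aromatic carbon, left the inhibition essentially where it was. Among the measured compounds shown here, no measured step shows what a 1-benzothiophen-2-yl, with its six-membered aromatic ring of carbon only, does at this place. Compound 4 is therefore expected to give about 58% in this assay, with a range from 42% to 74%. The expected step is a number 2.2 percentage points higher from compound 2 to compound 4 (within the scatter), a change not clearly beyond the scatter.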

Compound 4, a percentage reported as inhibition, at one concentration (the size of the read-out at that concentration, not a potency): 65.5%
For compound 4 the middle estimate is 7.5 percentage points below the measured one, within the range that was stated.
By their numbers in this assay, from the lowest: compounds 1, 2, 4 and 3 (each within the scatter of the next, the first and the last beyond it).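

In this assay, the aromatic carbon between two ring nitrogen atoms accepts a group that carries a six-membered aromatic ring of carbon only: 1-benzothiophen-2-yl, with 9 heavy atoms against 6 in 5-bromofuran-2-yl, gives a number 9.7 percentage points higher from compound 2 to compound 4 (within the scatter), so this exchange does not separate the two groups. Among these compounds, measured against the 4-bromophenyl group, the same entering group gives a number 10.8 percentage points higher from compound 1 to compound 4 (beyond the scatter), the first step at this place to clear the scatter, although only modestly, so the groups tried here are no longer all equivalent even though 5-bromofuran-2-yl cannot be told apart from either of the others. No measurement available here accounts for this small separation.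

The compounds shown leave open what a thiophen-2-yl without the fused carbon ring, or a saturated amine such as piperidin-1-yl, would give at this place, and so which part of 1-benzothiophen-2-yl carries the step. They also leave open whether this group would give a similar step on a core bearing the 4-fluorophenyl group of compound 3.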